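A few compounds are considered here, and "the series" means these few. Any claim that something is new, unique, unknown or untested is made for them only; others in the source may bear on it.

In a functional assay on the whole organism with Rattus norvegicus as the target, in the maximal electroshock model (a lower number here means that less compound is needed, a higher number that more compound is needed for the effect), compound 1 `CNc1ncnc2c1ncn2Cc1ccc(N)cc1` gives 25 mg/kg. Compound 2 `CC(C)(C)Nc1ncnc2c1ncn2Cc1ccccc1F` is reported in this assay only as a limit of the assay, > 50 mg/kg, the point where (the limit of > 50 mg/kg in this assay, at which 1 of the 2 values shown sits). Compound 3 `Nc1ncnc2c1ncn2Cc1ccccc1F` differs from compound 2 by hydrogen in place of tert-butyl on a nitrogen on an aromatic ring. Within the data shown here, no measured step covers this change, so what follows is an expectation. Compound 3 is expected to shift by an at least 1.6-fold lower number from compound 2 to compound 3 (0.22 log units; that floor lies within the scatter) in this assay, toward a number rather than a limit. That expectation rests on compound 1, which gives 25 mg/kg in this assay. Compound 3 is therefore estimated at 30 mg/kg, within 12 mg/kg to 80 mg/kg.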

Compound 3, dose for half-maximal effect: 4.5 mg/kg
Compound 3: middle estimate off by 6.7-fold (0.82 log units), on the high side, and the stated range ends above it.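

Replacing tert-butyl with hydrogen on this nitrogen gives an at least 11-fold lower number from compound 2 to compound 3 (1.04 log units; beyond the scatter) in this assay. This shows that the unsubstituted amino group is compatible with a low dose in this model, which compound 1 and compound 2, both substituted on that nitrogen, could not show. Compound 2 stands at a limit, so the step is only a floor: the limit of > 50 mg/kg in this assay, at which 1 of the 3 values shown sits.

Going by these compounds, how an ethyl or isopropyl group on that nitrogen would read in this assay stays open. On these data alone, compound 1 differs from compound 3 in more than one place, so the effect of its methyl group alone also stays open.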